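Adding a Dimethylamino Group to the Aryl Ring of Compound 2

The source may report more compounds than this note shows. Statements on the series, on what has been measured and on what is new or still open speak of the compounds shown alone.

Of the compounds shown here, three have so far been tested in a functional assay on HepG2 cells (Homo sapiens) for cytotoxicity, read by sulforhodamine B assay, with a stated time of 48 h; on this read-out higher numbers stand for weaker inhibition and lower numbers for stronger inhibition. Compound 1 `CSC(SC)=C(C#N)C(=O)N/N=C(\C)c1ccc(NS(=O)(=O)c2ccc(Cl)cc2)cc1` gives 19400 nM, compound 2 `CCOC(=O)c1c(-c2ccccc2)c(C#N)c(=O)n(/N=C(\C)c2ccc(NS(=O)(=O)c3ccc(Cl)cc3)cc2)c1N` gives 16800 nM, and compound 3 `CCOC(=O)c1c(-c2ccc(OC)cc2)c(C#N)c(=O)n(/N=C(\C)c2ccc(NS(=O)(=O)c3ccc(Cl)cc3)cc2)c1N` gives 61700 nM. Compound 2 has the lowest of the three numbers, though its gap to compound 1 lies within the usual scatter, so the two cannot be told apart; compound 3 lies clearly further off. Compound 4 `CCOC(=O)c1c(-c2ccc(N(C)C)cc2)c(C#N)c(=O)n(/N=C(\C)c2ccc(NS(=O)(=O)c3ccc(Cl)cc3)cc2)c1N` differs from compound 2 by dimethylamino in place of hydrogen on an aromatic carbon. Among the measured compounds shown here, the one measured step that bears on this is a 3.7-fold higher number from compound 2 to compound 3 (0.56 log units; beyond the scatter), where another group enters the same aromatic carbon. A step of similar direction and size is therefore expected here, a 2.7-fold higher number from compound 2 to compound 4 (0.43 log units; beyond the scatter), giving a higher number in this assay. Compound 4 is estimated at 45000 nM, within a range from 18000 nM to 110000 nM.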

Compound 4, half-maximal inhibitory concentration: 21000 nM
Estimate against measurement, compound 4: 2.1-fold (0.33 log units) above; the range from low to high includes it.
By their numbers in this assay, from the lowest: compounds 2, 1 and 4 (each within the scatter of the next); then compound 3.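

Dimethylamino in place of hydrogen gives a 1.3-fold higher number from compound 2 to compound 4 (0.10 log units; within the scatter) in this assay, so a group added at this ring carbon need not shift the number, and the rise seen with methoxy does not carry over to every group. The identity of the group therefore matters here: dimethylamino in place of methoxy gives a 2.9-fold lower number from compound 3 to compound 4 (0.47 log units; beyond the scatter) at the same carbon. Nothing measured here explains why these two groups differ.

Going by these compounds, it remains open how a chlorine or a carboxylic acid at this carbon would behave. Also open, on these data alone, is whether an amine with longer chains than dimethylamino would stay level with compound 2 or move away from it.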